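Working notes: from compound 3 to compound 4

This account rests on a few compounds, and the source may have more. Where it says the series, first, only, none or still open, it means among the compounds named here.

Measured so far in a functional assay on the whole organism with Mus musculus as the target; on this read-out lower numbers stand for an effect already at smaller amounts and higher numbers for an effect only at larger amounts of compound:
compound 1 `CN(CC(N)=O)Cc1ccc(OCc2cccc(Cl)c2)cc1` gives 114 mg/kg
compound 2 `CNC(=O)[C@H](NCc1ccc(OCc2ccccc2)cc1)C(C)C` gives 112 mg/kg
compound 3 `CNC(=O)[C@@H](CO)NCc1ccc(OCc2cccc(OC)c2)cc1` gives 109 mg/kg

Compound 3 (109 mg/kg) stands within the scatter of both compound 1 and compound 2, so the three values form no order. For the measured compounds named here, these compounds differ from one another in more than one place, and no measured pair isolates a single change. The effect of any one change in this series is therefore unknown from the data.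

The next compound, compound 4 `CNC(=O)[C@@H](CO)NCc1ccc(OCc2ccccc2F)cc1`, has not been measured. It carries 2-fluorophenyl in place of 3-methoxyphenyl on a saturated chain carbon bound to an oxygen on an aromatic ring.

In this assay no step beyond the scatter is expected, in either direction. This expectation rests on compound 1 (114 mg/kg) and compound 2 (112 mg/kg), whose values stay within the scatter of compound 3 despite their several structural differences. The estimated change, a 1.1-fold lower number from compound 3 to compound 4 (0.04 log units; within the scatter), is expected to stay within the scatter. For compound 4 an estimated value of 100 mg/kg is expected, with a range from 50 mg/kg to 190 mg/kg as the expected spread.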

Compound 4, dose for half-maximal effect: 12.4 mg/kg
Estimate against measurement, compound 4: 8.1-fold (0.91 log units) above; measured number outside the range, below it.
By their numbers in this assay, from the lowest: compound 4; then compounds 3, 2 and 1 (each within the scatter of the next).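

In this assay, the aryl group on a saturated chain carbon bound to an oxygen on an aromatic ring proves able to move the read-out: 2-fluorophenyl in place of 3-methoxyphenyl gives an 8.8-fold lower number from compound 3 to compound 4 (0.94 log units; beyond the scatter). For the compounds shown here, compounds 1, 2 and 3 showed no order and included no pair differing in one place, so their values could not show that this position responds to any change. With the rest of the structure shared by the two compounds, the step belongs to this single exchange, though the data offer no measured property that accounts for it.

The exchange removes a methoxy group and introduces a fluorine on the phenyl ring, and the compounds shown separate neither these two parts nor the role of where each group sits. Also open, on these data alone, are how a nitrile, a trifluoromethyl or an amine on that ring would compare with the 2-fluorophenyl group, and whether the exchange would have a similar effect on the core of compound 1 or compound 2.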